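A Methoxy Added to a Phenyl Ring on the Shared Core

This account rests on a few compounds, and the source may have more. Where it says the series, first, only, none or still open, it means among the compounds named here.

Compound 1 `COc1cc(N/C=C\C(=O)c2cn(-c3ccccc3)nc2-c2ccccc2)cc(OC)c1OC` was tested in a functional assay on PC-3 cells (Homo sapiens) for antiproliferative activity, read by MTT assay, with a stated time of 48 h (a higher number here means a weaker inhibitor, a lower number a stronger inhibitor), where compound 1 gives 5930 nM. Two related compounds built on the same core were measured alongside it. Compound 2 `O=C(/C=C\Nc1ccc(Cl)cc1)c1cn(-c2ccccc2)nc1-c1ccc(F)cc1` gives 3800 nM in this assay, and compound 3 `O=C(/C=C\Nc1ccc(O)cc1)c1cn(-c2ccccc2)nc1-c1ccc(Cl)cc1` gives 4430 nM. Compound 1 has the highest of the three numbers, yet its gap to compound 3 and its gap to compound 2 both fall within the usual scatter of repeated measurements, so the three compounds cannot be told apart on these numbers.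

Compound 4 `COc1ccc(-c2nn(-c3ccccc3)cc2C(=O)/C=C\Nc2cc(OC)c(OC)c(OC)c2)cc1` differs from compound 1 in a single place: methoxy in place of hydrogen on an aromatic carbon, para to a large group. Among the measured compounds shown here, no pair of measured compounds differs in only one place; a measured step to lean on is missing, and the three values simply sit close together. Against that background the step is expected to be small, in either direction, and not beyond the scatter: a 1.2-fold lower number from compound 1 to compound 4 (0.07 log units; within the scatter). In this assay compound 4 is estimated at 5000 nM, with a range from 2500 nM to 10000 nM.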

Compound 4, half-maximal inhibitory concentration: 18900 nM
Estimate against measurement, compound 4: 3.8-fold (0.58 log units) below; measured number outside the range, above it.
By their numbers in this assay, from the lowest: compounds 2, 3 and 1 (each within the scatter of the next); then compound 4.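

Placing a methoxy on this aromatic carbon, para to a large group, gives the first change at a single place on the shared core, and in this assay it comes with a 3.2-fold higher number from compound 1 to compound 4 (0.50 log units; beyond the scatter). Among the compounds shown here, this shows that the position is not indifferent to what it carries: here, phenyl to 4-methoxyphenyl goes with weaker inhibition, something the three closely spaced values of the earlier compounds could not show. No measurement at hand bears on why this step occurs.

One step cannot tell whether this result is particular to methoxy or would follow from other groups at this position. As far as these compounds go, how an amine, a carboxylic acid or a longer chain such as ethoxy would behave at this carbon remains open.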